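Dropping Chloro from Compound 3: Expected Cytotoxicity

This account rests on a few compounds, and the source may have more. Where it says the series, first, only, none or still open, it means among the compounds named here.

Compound 3 `CS(=O)(=O)c1ccc(NC(=O)CSc2nnc(N3C(=O)CSC3c3ccc(Cl)cc3)s2)cc1` was tested in an ADME assay on MT4 cells (Homo sapiens) for cytotoxicity, read by MTT assay, with a stated time of 5 days (on this read-out higher numbers stand for lower toxicity in this test and lower numbers for higher toxicity in this test), where compound 3 gives 116000 nM, the lowest of the two numbers measured. Compound 2 `O=C1CSC(c2ccc(Cl)cc2)N1c1n[nH]c(=S)s1` gives 195000 nM in this assay, a gap within the scatter, so the two cannot be ordered. Compound 1 `CS(=O)(=O)c1ccc(NC(=O)CSc2nnc(N3C(=O)CSC3c3ccccc3Cl)s2)cc1` reaches only a limit of the assay, >= 172000 nM. Compound 4 `CS(=O)(=O)c1ccc(NC(=O)CSc2nnc(N3C(=O)CSC3c3ccccc3)s2)cc1` differs from compound 3 in one place: hydrogen in place of chloro on an aromatic carbon. Among the compounds with values here, the only measured step, an at least 1.4-fold lower number from compound 1 to compound 3 (0.17 log units; that floor lies within the scatter), moves the chloro rather than removing it and stays within the scatter, so it bears only loosely on this change. No step beyond the scatter is therefore expected in this assay. Compound 4 is expected to give 130000 nM, within 60000 nM to 300000 nM, an expected step of a 1.1-fold higher number from compound 3 to compound 4 (0.05 log units; within the scatter).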

Compound 4, half-maximal cytotoxic concentration: 131000 nM
Compound 4: the middle estimate sits 1.0-fold (0.00 log units) below what was measured; the measured number falls inside the stated range.
By their numbers in this assay, from the lowest: compounds 3, 4 and 2 (each within the scatter of the next).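

Taking the chloro off the 4-chlorophenyl group altogether, rather than moving it, gives a 1.1-fold higher number from compound 3 to compound 4 (0.05 log units; within the scatter) in this assay, so on this ring the chlorine makes no difference that can be read. Starting from the 2-chlorophenyl group instead, the same change gives an at least 1.3-fold lower number from compound 1 to compound 4 (0.11 log units; that floor lies within the scatter). Compound 1 holds only a limit, so that step is a floor and not a size: the limit of >= 172000 nM in this assay, at which 1 of the 4 values shown sits.

From the compounds shown here alone, whether a different group on this ring, such as an amine, a carboxylic acid or a methoxy group, would move the number beyond the scatter stays open.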